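Oxime ether with ester chain in place of oximino ester

The source may hold more compounds than are shown below. What is called first, only, known or untested is meant among the compounds shown, and "the series" means these compounds.

Measured compounds:
- compound 1 `OC1O[C@H](CO/N=C2\CCc3cc(Sc4cc(F)cc(C5CCOCC5)c4)ccc32)[C@H](O)[C@H](O)[C@H]1O`: > 2500 nM
- compound 2 `CCOC(=O)/C(=N\O)c1ccc(Sc2cc(F)cc(C3CCOCC3)c2)cc1`: 170 nM
- compound 3 `C/C(=N\O)c1ccccc1Sc1cc(F)cc(C2CCOCC2)c1`: > 10000 nM

The three measured compounds share the diaryl thioether core of compound 2. Among the compounds with values here, in a functional assay (blood) for inhibition, with Homo sapiens as the target (on this read-out higher numbers stand for weaker inhibition and lower numbers for stronger inhibition), compound 2 gives 170 nM, the only value reported as a number in this set. Within the data shown here, for compound 1 the result is a limit of the assay, > 2500 nM, the one value that sits at the limit of > 2500 nM in this assay, at which 1 of the 3 values shown sits. Among the measured compounds shown here, for compound 3 the result is likewise a limit, > 10000 nM, the one value at the limit of > 10000 nM in this assay, at which 1 of the 3 values shown sits. For the measured compounds named here, compound 2 therefore stands as the only compound with a measured number.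

Compound 4 `CCOC(=O)CO/N=C(\C)c1ccc(Sc2cc(F)cc(C3CCOCC3)c2)cc1` has not yet been measured. It differs from compound 2 by a group of 10 heavy atoms (6 carbon, 1 nitrogen, 3 oxygen; no ring) in place of a group of 8 heavy atoms (4 carbon, 1 nitrogen, 3 oxygen; no ring), on an aromatic carbon. The group that enters carries no hydrogen-bond donor where the group that leaves carried one, and it places the ethyl ester at the end of an oxime ether chain rather than directly on the oxime carbon.

Compound 1, which also carries an oxime ether, gave only a limit, so a loss of inhibition is expected for compound 4. Compound 4 is expected at 900 nM, with a range from 250 nM to 4000 nM, meaning an estimated step of a 5.3-fold higher number from compound 2 to compound 4 (0.72 log units; beyond the scatter) beyond the usual scatter.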

Compound 4, half-maximal inhibitory concentration: 610 nM
Compound 4: middle estimate off by 1.5-fold (0.17 log units), on the high side; the measured number falls inside the stated range.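

In this assay, the change on an aromatic carbon para to a large group gives a 3.6-fold higher number from compound 2 to compound 4 (0.55 log units; beyond the scatter) and leaves compound 4 with a measured number, so the group that enters, with 0 hydrogen-bond donors and its ethyl ester at the end of an oxime ether chain, weakens inhibition without abolishing it. Compound 1, the other oxime ether shown, has only a limit of the assay, > 2500 nM, so compound 4 is the first oxime ether here to give a number. Nothing measured here explains the step, and it cannot be divided between the lost hydrogen-bond donor and the moved ester.

As far as these compounds go, it remains open how a simple methyl ether on the oxime oxygen, with the ethyl ester kept directly on the oxime carbon, would stand against compound 2, which would show what the capped oxime alone contributes. Also open, from the compounds shown here alone, is whether the ethyl ester at the end of the chain in compound 4 can give way to a carboxylic acid or an amide, and how a longer chain before the ester would read out.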